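Styryl Linker in Place of Methoxyphenyl: Expected Cytotoxicity

The compounds below may be only part of what the source reports. "The series", "measured", "known", "first", "only" and "open" are said of these compounds alone.

Compound 1, `CC(=O)c1cc(-c2ccc(F)cc2)cc2cc(-c3ccccc3)[nH]c12`: 36.4%
Compound 2, `COc1ccc(-c2cc(C(C)=O)c3[nH]c(-c4ccccc4)cc3c2)cc1`: 30.8%

In a functional assay on MCF7 cells (Homo sapiens) for cytotoxicity, read by MTT assay, with a stated time of 2 days, tested at 100 uM (a higher number here means a weaker effect of the compound at the concentration tested, a lower number a stronger effect), compound 1 gives 36.4% and compound 2 gives 30.8%. Going by the values given here, compound 2 has the lower of the two numbers, yet the only step, a number 5.6 percentage points lower from compound 1 to compound 2 (within the scatter), lies within the scatter, so neither compound can be called more active. Compound 3 `CC(=O)c1cc(/C=C/c2ccc(F)cc2)cc2cc(-c3ccccc3)[nH]c12` differs from compound 2 by 2-(4-fluorophenyl)ethenyl in place of 4-methoxyphenyl on an aromatic carbon. Among the compounds with values here, this change returns the fluorine seen in compound 1 and adds a double bond, and the one related step was within the scatter. No step beyond the scatter is therefore expected. Compound 3 is estimated at 34%, with a range from 20% to 52%. The expected step is a number 3.2 percentage points higher from compound 2 to compound 3 (within the scatter).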

Compound 3, a percentage reported as activity, at one concentration (the size of the read-out at that concentration, not a potency): 46.7%
Compound 3: middle estimate off by 12.7 percentage points, on the low side, within the range that was stated.
By their numbers in this assay, from the lowest: compounds 2 and 1 (each within the scatter of the next); then compound 3.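

The cleanest comparison in this assay is a number 10.3 percentage points higher from compound 1 to compound 3 (beyond the scatter), where 2-(4-fluorophenyl)ethenyl replaces 4-fluorophenyl, so the fluorine stays and the effect weakens as the double bond enters. Replacing 4-methoxyphenyl gives the same direction, with a number 15.9 percentage points higher from compound 2 to compound 3 (beyond the scatter), showing that this position responds to a change that the fluoro-to-methoxy swap did not reveal. No measurement here explains the weaker effect.

On these data alone, whether a 2-(4-fluorophenyl)ethyl group, with a single bond in place of the double bond, would behave like the ethenyl group stays open. So does the effect of an amine in place of the fluorine.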